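Compound 4 expected from the steps of compound 1

The source may report more compounds than this note shows. Statements on the series, on what has been measured and on what is new or still open speak of the compounds shown alone.

Values in an assay on isolated protein (Oryctolagus cuniculus) for inhibition of Calpain-2 catalytic subunit (Homo sapiens); on this read-out lower numbers stand for stronger inhibition and higher numbers for weaker inhibition:
compound 1, `CCC(NC(=O)C(CC(C)C)NC(=O)OCc1ccccc1)C(=O)C(=O)NCc1ccccc1`, gives 350 nM
compound 2, `CCC(NC(=O)C(CC(C)C)NC(=O)OCc1ccccc1)C(=O)C(=O)NCc1cccnc1`, gives 120 nM
compound 3, `CCC(NC(=O)C(CC(C)C)NC(=O)OCc1ccccc1)C(=O)C(=O)NCCCN1CCCc2ccccc21`, gives 200 nM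

Compound 1 has the highest number of the three; the nearest is compound 3, with a 1.8-fold lower number from compound 1 to compound 3 (0.24 log units; within the scatter), and the furthest compound 2, with a 2.9-fold lower number from compound 1 to compound 2 (0.46 log units; beyond the scatter). Compound 4, `CCC(NC(=O)C(CC(C)C)NC(=O)OCc1ccccc1)C(=O)C(=O)NCCCN1CCc2ccccc2C1`, differs from compound 1 by 2-(1,2,3,4-tetrahydroisoquinolin-2-yl)ethyl in place of phenyl on a saturated chain carbon bound to an amide-type nitrogen. The closest measured step is that to compound 3, where a related two-ring chain enters at the same place and gives a 1.8-fold lower number from compound 1 to compound 3 (0.24 log units; within the scatter); the step to compound 2 is the only one beyond the scatter. Together they suggest a small lowering, possibly within the scatter. Compound 4 is therefore expected at 200 nM, with a range of 100 nM to 400 nM, meaning an estimated 1.8-fold lower number from compound 1 to compound 4 (0.24 log units; within the scatter).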

Compound 4, inhibition constant: 190 nM
Compound 4: middle estimate off by 1.1-fold (0.02 log units), on the high side; the measured number falls inside the stated range.
By their numbers in this assay, from the lowest: compounds 2, 4, 3 and 1 (each within the scatter of the next, the first and the last beyond it).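

1,2,3,4-Tetrahydroisoquinolin-2-yl in place of 1,2,3,4-tetrahydroquinolin-1-yl gives a 1.1-fold lower number from compound 3 to compound 4 (0.02 log units; within the scatter) and so does not separate the two ring forms. Against phenyl, 2-(1,2,3,4-tetrahydroisoquinolin-2-yl)ethyl gives a 1.8-fold lower number from compound 1 to compound 4 (0.27 log units; within the scatter) and against pyridin-3-yl it gives a 1.6-fold higher number from compound 2 to compound 4 (0.20 log units; within the scatter) so at this place it stands apart from neither. Nothing available explains why these groups read alike.

Open, going by these compounds, is whether a morpholine or a carboxylic acid at the end of the same chain would move the number beyond the scatter. Also open, on these data alone, is what a longer chain carrying 1,2,3,4-tetrahydroisoquinolin-2-yl would give.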